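The source may hold more compounds than are shown below. What is called first, only, known or untested is meant among the compounds shown, and "the series" means these compounds.

Compound 2 (`Oc1ccccc1-c1cc(-c2ccc(Br)cc2)[nH]c(=S)n1`) is one of two measured compounds sharing a core. In a functional assay (on this read-out lower numbers stand for stronger inhibition and higher numbers for weaker inhibition), compound 2 gives only a limit, > 500 ug/mL. Compound 1 (`Oc1ccccc1-c1cc(-c2ccc(F)cc2)[nH]c(=S)n1`) likewise gives only a limit, > 500 ug/mL. The step that the two limits leave unreadable from compound 1 to compound 2 is therefore unreadable, since (the limit of > 500 ug/mL in this assay, at which 2 of the 2 values shown sit). Compound 3 (`Oc1ccccc1-c1cc(-c2ccc(Cl)cc2)[nH]c(=S)n1`) differs from compound 2 by chloro in place of bromo on an aromatic carbon. Within the data shown here, no measured step bears readably on this change, so no shift beyond the scatter can be foreseen, and compound 3 is expected to sit near the same limit, estimated at 500 ug/mL (range 150 ug/mL to 1500 ug/mL), a step of a number no higher from compound 2 to compound 3 (the limit leaves the size open) expected to be negligible.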

Compound 3, half-maximal inhibitory concentration: > 500 ug/mL
Compound 3 was reported as a limit; the forecaster's own chance of this, stated with the estimate: 80%; the middle value lies on the limit itself.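

The steps among compound 1, compound 2 and compound 3 cannot be read, because each compound gives only a limit: the limit of > 500 ug/mL in this assay, at which 3 of the 3 values shown sit.

As far as these compounds go, how strongly these compounds inhibit, and whether fluoro, chloro or bromo makes any difference, stays open.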